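Swapping the aryl group on a sulfur

The compounds below may be only part of what the source reports. "The series", "measured", "known", "first", "only" and "open" are said of these compounds alone.

In a functional assay on HeLa cells (Homo sapiens) for inhibition, read by CCK-8 assay, with a stated time of 72 h, tested at 2 uM (on this read-out higher numbers stand for more inhibition of growth at the one concentration tested and lower numbers for less inhibition of growth), compound 2 `Nc1ccccc1NC(=O)/C=C/c1ccc(CSc2ccc(Cl)cc2)cc1` gives 1.94% while compound 1 `COc1ccc(SCc2ccc(/C=C/C(=O)Nc3ccccc3N)cc2)cc1OC` gives 10.1% and these two values sit within the usual scatter of each other. Compound 3 `Nc1ccccc1NC(=O)/C=C/c1ccc(CSc2cccc(F)c2)cc1` has 3-fluorophenyl in place of 4-chlorophenyl on a sulfur and has not yet been measured. Going by the values given here, the only measured change at that sulfur gave a number 8.2 percentage points lower from compound 1 to compound 2 (within the scatter) and so no step beyond the scatter is expected here. The expected size of the new step is a number 4.1 percentage points higher from compound 2 to compound 3 (within the scatter) in this estimate. Compound 3 is expected at 6% with a range from 0% to 17% in this estimate.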

Compound 3, percent growth inhibition at one concentration: 2.25%
Estimate against measurement, compound 3: 3.8 percentage points above; the range from low to high includes it.
By their numbers in this assay, from the lowest: compounds 2, 3 and 1 (each within the scatter of the next).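

Changing the group on the sulfur from 4-chlorophenyl to 3-fluorophenyl gives, in this assay, a number 0.3 percentage points higher from compound 2 to compound 3 (within the scatter), and changing it from 3,4-dimethoxyphenyl to 3-fluorophenyl gives a number 7.9 percentage points lower from compound 1 to compound 3 (within the scatter). A third aryl group on this sulfur therefore also falls within the scatter of the other two, so at this one concentration the assay cannot separate these three compounds. No available evidence explains this result. Going by these compounds, it remains open whether a different kind of group on this sulfur, such as an amine or a carboxylic acid, would give a clearly different number.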